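Estimating HepG2 Cytotoxicity After an Acyl Group Swap

The compounds below may be only part of what the source reports. "The series", "measured", "known", "first", "only" and "open" are said of these compounds alone.

Values measured in an ADME assay on HepG2 cells (Homo sapiens) for cytotoxicity (on this read-out higher numbers stand for lower toxicity in this test and lower numbers for higher toxicity in this test), are shown here
Compound 1 (`CCCC[C@@H](/C=C/S(=O)(=O)c1ccccc1)NC(=O)c1cccc2cccnc12`) gives 36500 nM
Compound 2 (`C[C@H]1CC(C)(C)Nc2c(C(=O)N[C@H](/C=C/S(=O)(=O)c3ccccc3)CCc3ccccc3)cccc21`) gives the limit > 300000 nM
Compound 3 (`O=C(N[C@H](/C=C/S(=O)(=O)c1ccccc1)CCc1ccccc1)c1cccc2c1NCCC2`) gives the limit > 160000 nM

Compound 3 has no exact value in this assay and stands only at a limit, > 160000 nM as its reading. Compound 2 also reaches only a limit. Among the measured compounds shown here, compound 1 is the one compound with an exact number, and this number is lower than either limit.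

The unmeasured compound 4 (`Cn1cc([N+](=O)[O-])nc1C(=O)N[C@H](/C=C/S(=O)(=O)c1ccccc1)CCc1ccccc1`) has 1-methyl-4-nitro-1H-imidazol-2-yl in place of 1,2,3,4-tetrahydroquinolin-8-yl on a carbonyl carbon. The counted difference is given here (1-methyl-4-nitro-1H-imidazol-2-yl in place of 1,2,3,4-tetrahydroquinolin-8-yl on a carbonyl carbon). For the measured compounds named here, no measured pair of compounds isolates this swap, so the forecast is uncertain. Compound 1 at 36500 nM shows that a number can be obtained with a different acyl group, so a modest move toward lower numbers and higher toxicity seems reasonable. The expected change is an at least 2.0-fold lower number from compound 3 to compound 4 (0.30 log units; that floor lies within the scatter) in this assay as a rough estimate. Compound 4 is estimated at 80000 nM with an expected range of 25000 nM to 300000 nM in this assay when tested.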

Compound 4, half-maximal cytotoxic concentration: 28800 nM
Beside the measured number, compound 4's estimate is 2.8-fold (0.44 log units) above it, within the range that was stated.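

Putting 1-methyl-4-nitro-1H-imidazol-2-yl in place of 1,2,3,4-tetrahydroquinolin-8-yl on a carbonyl carbon gives, in this assay, an at least 5.5-fold lower number from compound 3 to compound 4 (0.74 log units; beyond the scatter). Among the compounds shown here, this is the first change in one place alone that can be read here, and it shows that the group on this carbonyl carbon can by itself move the read-out while the rest of the molecule stays the same. The true size of the step stays open-ended because compound 3 has only a limit and no exact number: the limit of > 160000 nM in this assay, at which 1 of the 4 values shown sits.

With a single replacement at this place, the compounds shown do not reveal which part of the entering group matters, whether its nitro group, its methyl group or its five-membered ring. As far as these compounds go, how a plain phenyl ring, or a ring carrying an amine or a carboxylic acid, would read on the same carbonyl carbon also remains open.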